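The compounds below may be only part of what the source reports. "The series", "measured", "known", "first", "only" and "open" are said of these compounds alone.

Measured so far:
Compound 1, `COC(=O)c1ccc(-c2cn(CC(=O)Nc3nc(C)cs3)nn2)cc1`, in a functional assay on BMDM cells (Mus musculus, strain C57BL/6) for inhibition, with a stated time of 2 days; on this read-out lower numbers stand for stronger inhibition and higher numbers for weaker inhibition: > 30000 nM
Compound 2, `O=C(Cn1cc(-c2ccc([N+](=O)[O-])cc2)nn1)Nc1nc2ccccc2s1`, in this assay: 3280 nM
Compound 3, `N#Cc1ccc(-c2cn(CC(=O)Nc3nc4ccccc4s3)nn2)cc1`, in this assay: > 30000 nM

Compound 3 stands at the limit of the assay: its value is a limit and not a number. Compound 1 also stands at that limit, which is the limit of > 30000 nM in this assay, at which 2 of the 3 values shown sit. Among the compounds with values here, compound 2 alone gives a number, and the single measured step is an at least 9.1-fold higher number from compound 2 to compound 3 (0.96 log units; beyond the scatter), a change of nitro to cyano that ends at the limit.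

The next step leads to compound 4, `COC(=O)c1ccc(-c2cn(CC(=O)Nc3nc4ccccc4s3)nn2)cc1`. The change is methoxycarbonyl in place of cyano on an aromatic carbon. Within the data shown here, no measured step bears directly on this exchange; the step from compound 2 to compound 3 concerns a different group. Compound 1 carries the same methoxycarbonyl group on the same ring and sits at the limit. On this basis no step beyond the scatter is expected, and compound 4 is expected most likely to remain at the limit, which means an expected step of a number no higher from compound 3 to compound 4 (the limit leaves the size open). The estimate for compound 4 in this assay is 30000 nM, in the range 10000 nM to 30000 nM.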

Compound 4, half-maximal inhibitory concentration: > 30000 nM
Compound 4 was reported as a limit; the forecaster's own chance of this, stated with the estimate: 70%; the middle value lies on the limit itself.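

In this assay compound 4 gives > 30000 nM, which is a limit and not a number. On the aromatic carbon para to a large group, methoxycarbonyl in place of nitro gives an at least 9.1-fold higher number from compound 2 to compound 4 (0.96 log units; beyond the scatter), so a second group besides cyano now falls short of the number seen with nitro. The steps joining compound 4 to compound 3 and to compound 1 cannot be read, and this limit now holds most of the set: the limit of > 30000 nM in this assay, at which 3 of the 4 values shown sit.

As far as these compounds go, the true values of compound 1, compound 3 and compound 4 stay open, so cyano and methoxycarbonyl cannot be ordered, nor can 1,3-benzothiazol-2-yl and 4-methyl-1,3-thiazol-2-yl. From the compounds shown here alone, it also stays open whether nitro is alone in giving a number, or whether an amine or a carboxylic acid at this place would give one too.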